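Substituted benzoate esters on the phenol of compound 1

This account rests on a few compounds, and the source may have more. Where it says the series, first, only, none or still open, it means among the compounds named here.

The series shares the core of compound 1 `COC(=O)/C(=C\c1ccc(O)cc1)Sc1ccnc2cc(Cl)ccc12`, which in a functional assay on HL-60 cells (Homo sapiens) for cytotoxicity, read by MTT assay, with a stated time of 24 h (a lower number here means a stronger inhibitor, a higher number a weaker inhibitor), gives 4310 nM. Compound 2 `COC(=O)/C(=C\c1ccc(OC(=O)c2ccc(OC)c(OC)c2)cc1)Sc1ccnc2cc(Cl)ccc12`, its (3,4-dimethoxyphenyl)carbonyl ester, gives 5290 nM in this assay, and the step of a 1.2-fold higher number from compound 1 to compound 2 (0.09 log units; within the scatter) is within the scatter. Among the two numbers shown, compound 2 stands highest, with compound 1 nearest at a difference within the scatter; the third value is a limit. Compound 3 `COC(=O)/C(=C\c1ccc(OC(=O)c2cc(OCc3ccccc3)c(OCc3ccccc3)c(OCc3ccccc3)c2)cc1)Sc1ccnc2cc(Cl)ccc12` gives only a limit of > 100000 nM in this assay. That a value sits at the limit of > 100000 nM in this assay, at which 1 of the 3 values shown sits, leaves the upper end of the series open.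

Compound 4 `COC(=O)/C(=C\c1ccc(OC(=O)c2cc(OC)c(OC)c(OC)c2)cc1)Sc1ccnc2cc(Cl)ccc12` is not yet measured. It differs from compound 2 by methoxy in place of hydrogen on an aromatic carbon. Within the data shown here, the only measured step that bears on this change is a 1.2-fold higher number from compound 1 to compound 2 (0.09 log units; within the scatter), the attachment of the whole dimethoxybenzoate, which stayed within the scatter; no measured step adds a single methoxy to that ring. Compound 3 carries benzyloxy groups on the same ring and reaches only a limit, so the upward direction is the less certain one. For compound 4 the expected step is a 1.3-fold higher number from compound 2 to compound 4 (0.12 log units; within the scatter), within the scatter. Compound 4 is therefore estimated at 7000 nM, with a range from 3000 nM to 25000 nM in this assay.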

Compound 4, half-maximal inhibitory concentration: 4240 nM
Compound 4: middle estimate off by 1.7-fold (0.22 log units), on the high side; measured number inside the range.
By their numbers in this assay, from the lowest: compounds 4, 1 and 2 (each within the scatter of the next). At a limit, above all of these: compound 3.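

The change from 3,4-dimethoxyphenyl to 3,4,5-trimethoxyphenyl gives the only measured addition of a single methoxy to this ring, and in this assay it reads as a 1.2-fold lower number from compound 2 to compound 4 (0.10 log units; within the scatter). The earlier step, a 1.2-fold higher number from compound 1 to compound 2 (0.09 log units; within the scatter), covered only the attachment of the whole dimethoxybenzoate; the new step shows that a methoxy on this aromatic carbon, ortho to a methoxy group and meta to a large group, also leaves the number within the scatter. Compound 3, which carries benzyloxy groups on the same ring, remains a limit of the assay, and the new step does not account for it: the limit of > 100000 nM in this assay, at which 1 of the 4 values shown sits.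

On these data alone, compounds 2 and 4 differ only by one small ether group, so it remains open whether this carbon stays as undemanding with a hydroxy, an amine, a carboxylic acid or a longer alkoxy chain such as propoxy in place of methoxy. Also open, as far as these compounds go, is where between methoxy and benzyloxy the number leaves the range of compounds 2 and 4, and whether a single benzyloxy on this ring is enough to do so.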